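This account rests on a few compounds, and the source may have more. Where it says the series, first, only, none or still open, it means among the compounds named here.

Compound 1 `CCCS(=O)(=O)Nc1ccc(F)c(C(=O)c2n[nH]c3ncc(-c4ccccc4C)cc23)c1F` and compound 2 `CCCS(=O)(=O)Nc1ccc(F)c(C(=O)c2n[nH]c3ncc(-c4cccc(N(C)C)c4)cc23)c1F` share one core and differ only in the aromatic ring attached to it. In an assay for binding affinity to dual specificity mitogen-activated protein kinase kinase 4 (Homo sapiens), read by KINOMEscan, tested at 100 nM (a higher number here means a weaker effect of the compound at the concentration tested, a lower number a stronger effect), compound 1 gives 7%, while compound 2 gives 26%, the higher of the two numbers, so compound 2 acts more weakly than compound 1 at this concentration. Among the compounds with values here, the step of a number 19 percentage points higher from compound 1 to compound 2 (beyond the scatter) is the only measured step here, and it is modest.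

Compound 3 `CCCS(=O)(=O)Nc1ccc(F)c(C(=O)c2n[nH]c3ncc(-c4ccc(Cl)cc4Cl)cc23)c1F` has not yet been measured. It differs from compound 2 in a single place: 2,4-dichlorophenyl in place of 3-(dimethylamino)phenyl on an aromatic carbon. The entering 2,4-dichlorophenyl has no hydrogen-bond acceptor, like the 2-methylphenyl of compound 1, whereas the leaving 3-(dimethylamino)phenyl has one. Within the data shown here, the only step that bears on this change is a number 19 percentage points higher from compound 1 to compound 2 (beyond the scatter), which raised the number when the 3-(dimethylamino)phenyl came in; removing it again is expected to reverse most of that. The expected step is a number 16 percentage points lower from compound 2 to compound 3 (beyond the scatter), downward and beyond the scatter. Compound 3 is therefore estimated at 10%, with a likely range from 2% to 30%.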

Compound 3, a percentage reported as activity, at one concentration (the size of the read-out at that concentration, not a potency): 22%
Beside the measured number, compound 3's estimate is 12 percentage points below it; the measured number falls inside the stated range.
By their numbers in this assay, from the lowest: compound 1; then compounds 3 and 2 (each within the scatter of the next).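

In this assay the exchange of 3-(dimethylamino)phenyl for 2,4-dichlorophenyl gives a number 4 percentage points lower from compound 2 to compound 3 (within the scatter) at this position, so two rings carrying quite different substituents read alike here. Two rings without a hydrogen-bond acceptor still give a number 15 percentage points higher from compound 1 to compound 3 (beyond the scatter) when 2-methylphenyl is replaced by 2,4-dichlorophenyl, so the lack of an acceptor is not enough on its own to match the low number of the 2-methylphenyl ring. Nothing given here explains why the 2-methylphenyl ring stands apart from the other two.

The three compounds leave open which feature of the 2-methylphenyl ring goes with its low number, and whether an unsubstituted phenyl or a phenyl carrying a single methoxy group would read like compound 1 or like compound 2 and compound 3. It also remains open how a primary amine or a carboxylic acid on this ring would read, and whether the pattern seen among these three rings would hold at other concentrations, since each compound has only a single reading at one concentration.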